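The source may report more compounds than this note shows. Statements on the series, on what has been measured and on what is new or still open speak of the compounds shown alone.

Of the compounds shown here, two of a shared amide series have been measured in a functional assay on cells for positive allosteric modulation of metabotropic glutamate receptor 5 (Rattus norvegicus), read by calcium flux; on this read-out higher numbers stand for an effect only at larger amounts of compound and lower numbers for an effect already at smaller amounts. Compound 1 `COc1cccc(C(=O)Nc2cc(-c3ccccc3)nn2-c2ccccc2)c1` carries a 3-methoxyphenyl on its carbonyl carbon, and in this assay compound 1 gives 102 nM, the lower of the two numbers recorded. Compound 2 `COc1cccc(-c2cc(NC(=O)c3ccccc3)n(-c3ccccc3)n2)c1` differs from it in more than one place, and in this assay compound 2 gives 600 nM; the gap between these two values lies beyond the usual scatter, so compound 1 is the more potent of the pair on this reading.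

Compound 3 `Cc1ccc(C(=O)Nc2cc(-c3ccccc3)nn2-c2ccccc2)cn1` has not yet been measured. It differs from compound 1 in one place: 6-methylpyridin-3-yl in place of 3-methoxyphenyl on a carbonyl carbon. Among the compounds with values here, nothing measured so far isolates this kind of exchange on the carbonyl carbon, so no directly comparable step is available. The expectation is a modest change, with the number for compound 3 judged more likely to rise somewhat than to fall, expressed as a step of a 2.0-fold higher number from compound 1 to compound 3 (0.29 log units; within the scatter). On that basis, compound 3 is estimated to give about 200 nM in this assay, within a range from 60 nM to 700 nM.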

Compound 3, half-maximal effective concentration: 280 nM
Beside the measured number, compound 3's estimate is 1.4-fold (0.15 log units) below it, and the stated range covers the measured number.
By their numbers in this assay, from the lowest: compound 1; then compound 3; then compound 2.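

Within the data shown here, this is the first exchange that can be read at a single place: in this assay, 6-methylpyridin-3-yl in place of 3-methoxyphenyl on the carbonyl carbon gives a 2.7-fold higher number from compound 1 to compound 3 (0.44 log units; beyond the scatter), a modest step but one beyond the usual scatter of repeated measurements. It shows that the number responds to which six-membered aromatic ring sits on the carbonyl carbon, even though the two groups match in their counted hydrogen-bond donors and acceptors and neither carries a net charge, so those counts alone do not separate them. Nothing measured here offers an explanation for the step.

The exchange alters several things at once, replacing a ring carbon with a ring nitrogen and a methoxy group with a methyl group, and the compounds shown cannot say how much of the step belongs to each. A plain phenyl, a pyridine ring without the methyl group, or a ring bearing an amine or a carboxylic acid on the carbonyl carbon would be needed to pull these parts apart and to show how widely this position tolerates change.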